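This account rests on a few compounds, and the source may have more. Where it says the series, first, only, none or still open, it means among the compounds named here.

Measured so far:
compound 1, `O=C(CCc1cccc2c1B(O)OC2)Nc1ccc(Br)cc1`: 5300 nM
compound 2, `C#Cc1cccc(NC(=O)CCc2cccc3c2B(O)OC3)c1`: 1600 nM

Both compounds share one core and differ only in the group carried on the anilide ring. In a functional assay on MDA-MB-231 cells (Homo sapiens) for antiproliferative activity, read by MTT assay, with a stated time of 72 h (on this read-out higher numbers stand for weaker inhibition and lower numbers for stronger inhibition), compound 2 gives the lower of the two numbers, and compound 1, whose number is the higher one, lies beyond the usual scatter from it, so compound 2 is the stronger inhibitor of the pair shown.

Compound 3, `N#Cc1cccc(-c2cccc(NC(=O)CCc3cccc4c3B(O)OC4)c2)c1`, has not yet been measured in this assay. Compared with compound 2 its change is 3-cyanophenyl in place of ethynyl on an aromatic carbon. Among the compounds with values here, no pair of measured compounds shows what such a change does, so the expectation rests on compound 2 alone. Compound 3 is expected to give a number close to that of compound 2, with a step of a 1.1-fold lower number from compound 2 to compound 3 (0.03 log units; within the scatter) that is not expected to go beyond the scatter. The estimate for compound 3 is 1500 nM, with a range from 400 nM to 5500 nM.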

Compound 3, half-maximal inhibitory concentration: 110 nM
Beside the measured number, compound 3's estimate is 14-fold (1.13 log units) above it, outside the stated range (below it).
By their numbers in this assay, from the lowest: compound 3; then compound 2; then compound 1.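

In this assay, this aromatic carbon takes a whole additional six-membered aromatic ring and the number improves sharply: putting 3-cyanophenyl in place of ethynyl gives a 15-fold lower number from compound 2 to compound 3 (1.16 log units; beyond the scatter). Neither earlier compound carries a second aromatic ring on this part of the molecule, so they gave no sign that a change here could have so large an effect. Nothing available explains the size of this step, and the data give no measured property of either group that bears on it.

The new group brings in a ring and a nitrile together, so the compounds shown leave open which of the two matters for the step. A plain phenyl group, or the same ring with an amine or a carboxylic acid in place of the nitrile, would help to separate them.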